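A swap on the sulfonyl sulfur

A few compounds are considered here, and "the series" means these few. Any claim that something is new, unique, unknown or untested is made for them only; others in the source may bear on it.

Measured so far in an ADME assay on the whole organism (Rattus norvegicus, strain Harlan-Han Wistar) for pharmacokinetics; on this read-out lower numbers stand for slow clearance and higher numbers for fast clearance:
- Compound 1 `Cc1ccc2[nH]c(C(=O)N[C@H]3CN(S(=O)(=O)c4ccnnc4)C[C@@H]3C(=O)NCCN(C)C)cc2c1`: 34 mL/min/kg
- Compound 2 `Cc1ccc2[nH]c(C(=O)N[C@H]3CN(S(=O)(=O)c4ccnc(C)c4)C[C@@H]3C(=O)NCCN(C)C)cc2c1`: 66 mL/min/kg

In this assay, compound 2 gives 66 mL/min/kg, which lies within the scatter of compound 1. The next compound to be measured is compound 3 `Cc1ccc2[nH]c(C(=O)N[C@H]3CN(S(=O)(=O)c4cn(C)nc4C)C[C@@H]3C(=O)NCCN(C)C)cc2c1`, and the change is again on the sulfonyl sulfur: 1,3-dimethyl-1H-pyrazol-4-yl in place of 2-methylpyridin-4-yl on a sulfonyl sulfur. For the measured compounds named here, one measured step bears on this change: a 1.9-fold higher number from compound 1 to compound 2 (0.29 log units; within the scatter). That step also exchanged the aromatic ring on the sulfonyl sulfur, and it stayed within the scatter. Going by the values given here, no measured compound has a five-membered aromatic ring at this place, so the evidence is indirect. No step beyond the scatter is therefore expected in this assay. The expected change is a 1.4-fold lower number from compound 2 to compound 3 (0.14 log units; within the scatter). Compound 3 is estimated at 48 mL/min/kg, with an expected range of 24 mL/min/kg to 95 mL/min/kg.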

Compound 3, clearance: 45 mL/min/kg
For compound 3 the middle estimate is 1.1-fold (0.03 log units) above the measured one; low and high end bracket the measured number.
By their numbers in this assay, from the lowest: compounds 1, 3 and 2 (each within the scatter of the next).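

In this assay, 1,3-dimethyl-1H-pyrazol-4-yl on the sulfonyl sulfur in place of 2-methylpyridin-4-yl gives a 1.5-fold lower number from compound 2 to compound 3 (0.17 log units; within the scatter) and, in place of pyridazin-4-yl, gives a 1.3-fold higher number from compound 1 to compound 3 (0.12 log units; within the scatter) as the second comparison. The exchange of a six-membered aromatic ring for a five-membered one therefore produces no step beyond the scatter at this place, and all three compounds lie within the scatter of each other. No accompanying measurement offers an explanation for these numbers.

From the compounds shown here alone, whether a group without an aromatic ring at this place, such as a cyclopropyl or a plain methyl, would move the clearance beyond the scatter remains open. So does the contribution of the methyl groups on the pyrazole, which an unsubstituted pyrazol-4-yl would address.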